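Benzyl variation on a purine-like core in B-cell activation

The compounds below may be only part of what the source reports. "The series", "measured", "known", "first", "only" and "open" are said of these compounds alone.

Measured so far:
compound 1 `C=CCN1C(=C(C(=O)OCC)C(=O)OCC)N([C@H]2OC(CO)[C@H]3OC(C)(C)O[C@H]32)c2cc(N)nc(O)c21` — 0%
compound 2 `Nc1nc(O)c2c(n1)n(C1OC(CO)[C@@H](O)[C@H]1O)c(=O)n2Cc1ccc(Cl)c(Cl)c1` — 55%

In a functional assay on the whole organism (B cells) with Mus musculus as the target (on this read-out lower numbers stand for smaller maximal responses and higher numbers for larger maximal responses), compound 2 gives 55%, the higher of the two numbers; compound 1 gives 0%, far below it and beyond the scatter. The two share no single-point difference, so their gap is only noted.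

Compound 3 `N#Cc1ccc(Cn2c(=O)n(C3OC(CO)[C@@H](O)[C@H]3O)c3nc(N)nc(O)c32)cc1` differs from compound 2 by 4-cyanophenyl in place of 3,4-dichlorophenyl on a saturated chain carbon bound to an aromatic nitrogen. Among the compounds with values here, no measured pair carries this change, so the expected step from compound 2 to compound 3 is a number 15 percentage points lower from compound 2 to compound 3 (beyond the scatter), a modest fall that may still sit within the scatter. For compound 3 the estimate in this assay is 40%, with an expected range from 10% to 65%.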

Compound 3, largest response reached (reported as maximal response), in percent of the reference or control that the assay uses: 50%
For compound 3 the middle estimate is 10 percentage points below the measured one; low and high end bracket the measured number.
By their numbers in this assay, from the lowest: compound 1; then compounds 3 and 2 (each within the scatter of the next).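

In this assay, within the data shown here, 4-cyanophenyl in place of 3,4-dichlorophenyl on a saturated chain carbon bound to an aromatic nitrogen gives a number 5 percentage points lower from compound 2 to compound 3 (within the scatter), the first step that can be read at a single place. The two groups cannot be told apart on this read-out, although the entering group counts a hydrogen-bond acceptor that the leaving group lacks. Nothing in hand bears on why they read alike.

Still open, going by these compounds, is how far this place accepts other groups: an unsubstituted benzyl, a carboxylic acid or amine on the ring, or a longer chain would test it. The gap to compound 1 cannot be read, since it differs from the others in more than one place.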